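A few compounds are considered here, and "the series" means these few. Any claim that something is new, unique, unknown or untested is made for them only; others in the source may bear on it.

In an ADME assay on microsomes from liver (Rattus norvegicus) for metabolic stability, with a stated time of 10 min (on this read-out higher numbers stand for a more stable compound and lower numbers for a less stable compound), the starting point is compound 1 `CC(C)OC(=O)NCCS(=O)(=O)NC(=O)c1ccc(Nc2nc(NC3(c4ccc(Cl)cc4)CC3)nc(OCC(F)(F)F)n2)cc1`, which gives 73%. Within the data shown here, compound 2 `Cc1ccccc1S(=O)(=O)NC(=O)c1ccc(Nc2nc(NC3(c4ccc(Cl)cc4)CC3)nc(OCC(F)(F)F)n2)cc1` gives 100%, and the change a number 27 percentage points higher from compound 1 to compound 2 (beyond the scatter) is the only measured step in the set. Among the measured compounds shown here, compound 3 `O=C(NS(=O)(=O)CCNC(=O)C1CC1)c1ccc(Nc2nc(NC3(c4ccc(Cl)cc4)CC3)nc(OCC(F)(F)F)n2)cc1` stands apart: in this assay compound 3 is reported as "not active" (no number reported), with no single number, so no step from it can be computed. Compound 4 `CC(C)NC(=O)NCCS(=O)(=O)NC(=O)c1ccc(Nc2nc(NC3(c4ccc(Cl)cc4)CC3)nc(OCC(F)(F)F)n2)cc1` differs from compound 3 by isopropylamino in place of cyclopropyl on a carbonyl carbon. The measured step concerns a different group on the sulfonyl sulfur and bears only loosely on this change; compound 4 resembles compound 1 in its chain more closely than compound 3 does. Compound 4 is therefore expected to give about 70% in this assay, estimated between 45% and 95%.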

Compound 4, percent of the compound remaining: 97%
Estimate against measurement, compound 4: 27 percentage points below; the whole stated range lies below it.
By their numbers in this assay, from the lowest: compound 1; then compounds 4 and 2 (each within the scatter of the next).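

Isopropylamino in place of isopropoxy on a carbonyl carbon gives a number 24 percentage points higher from compound 1 to compound 4 (beyond the scatter) in this assay and shows that this one exchange within the chain matters to the read-out. The step of a number 3 percentage points lower from compound 2 to compound 4 (within the scatter) for 2-((isopropylcarbamoyl)amino)ethyl in place of 2-methylphenyl on a sulfonyl sulfur shows that an open chain can match the aryl group here, while the step from compound 3 to compound 4 cannot be read. No measurement given here accounts for the change. As far as these compounds go, whether methylamino or tert-butylamino on that carbonyl carbon, or a longer chain on the sulfonyl sulfur, would read the same stays open.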